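From tert-butyl to butyl on a shared core

The source may hold more compounds than are shown below. What is called first, only, known or untested is meant among the compounds shown, and "the series" means these compounds.

Compound 1 `CN(CCn1c(=N)sc2cc(OC(F)(F)F)ccc21)Cc1ccccc1`: 7 mg/kg
Compound 2 `CN(C)CCn1c(=N)sc2cc(C(C)(C)C)ccc21`: > 10 mg/kg
Compound 3 `CC[S+]([O-])CCn1c(=N)sc2cc(C(C)(C)C)ccc21`: > 10 mg/kg

In a functional assay on the whole organism with Rattus norvegicus as the target (on this read-out higher numbers stand for an effect only at larger amounts of compound and lower numbers for an effect already at smaller amounts), compound 1 gives a true number, 7 mg/kg. Compound 2 gives only a limit, > 10 mg/kg. Compound 3 also gives only a limit, > 10 mg/kg. The data so far therefore show (the limit of > 10 mg/kg in this assay, at which 2 of the 3 values shown sit).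

Compound 4 `CCCCc1ccc2c(c1)sc(=N)n2CC[S+]([O-])CC` has butyl in place of tert-butyl on an aromatic carbon. Among the compounds with values here, the only measured step, a step that the two limits leave unreadable from compound 2 to compound 3, changes a different group, so no measured step bears on this change. With compound 3 known only through the limit > 10 mg/kg, no step beyond the usual scatter is expected in this assay, in either direction. The expected size is a step that the limit leaves unreadable from compound 3 to compound 4. Compound 4 is estimated at 12 mg/kg, with an expected range of 5 mg/kg to 30 mg/kg.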

Compound 4, dose for half-maximal effect: > 10 mg/kg
Compound 4: no number, only a limit; the forecaster's own chance of this, stated with the estimate: 60%; the middle value does not contradict the limit.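

Within the data shown here, compound 4 gives only a limit, > 10 mg/kg, so, as compound 3 is also known only through a limit, no step between compound 3 and compound 4 can be read. Whether butyl and tert-butyl differ at all in this assay stays open, since most results sit at one limit: the limit of > 10 mg/kg in this assay, at which 3 of the 4 values shown sit.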